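The compounds below may be only part of what the source reports. "The series", "measured", "known", "first", "only" and "open" are said of these compounds alone.

Compound 1 `Cn1c(C(=O)O)cc2cc(OCCCC3CCN(Cc4ccccc4)CC3)ccc21` and compound 2 `C#CCNC(=O)c1cc2cc(OCCCC3CCN(Cc4ccccc4)CC3)ccc2n1C` share one core. In an assay on isolated protein for inhibition of Amine oxidase [flavin-containing] B (Homo sapiens), read by fluorescence, with stated times of 30 min and 1 h (a lower number here means a stronger inhibitor, a higher number a weaker inhibitor), compound 1 reaches only a limit, > 100000 nM. In this assay compound 2 likewise reaches only a limit, > 100000 nM. The step that the two limits leave unreadable from compound 1 to compound 2 therefore cannot be read because of the limit of > 100000 nM in this assay, at which 2 of the 2 values shown sit. Compound 3 `Cn1c(CO)cc2cc(OCCCC3CCN(Cc4ccccc4)CC3)ccc21` differs from compound 2 by hydroxymethyl in place of propargylcarbamoyl on an aromatic carbon. Among the measured compounds shown here, no measured step bears on this change, so nothing in this assay points in either direction beyond the fact that both values shown sit at a limit. Compound 3 is expected near 150000 nM in this assay, within 20000 nM to 1000000 nM, an expected step that the limit leaves unreadable from compound 2 to compound 3.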

Compound 3, half-maximal inhibitory concentration: > 100000 nM
Compound 3: no number, only a limit (the forecaster's own chance of this, stated with the estimate: 75%); the middle value is on the limit's open side.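

In this assay compound 3 also reaches only a limit, > 100000 nM. The steps to it from compound 1 and compound 2 therefore cannot be read: the limit of > 100000 nM in this assay, at which 3 of the 3 values shown sit. The compounds shown leave open whether any of these three groups on the aromatic carbon gives stronger inhibition than another.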